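The source may report more compounds than this note shows. Statements on the series, on what has been measured and on what is new or still open speak of the compounds shown alone.

Working notes on the series. Compound 1 `COc1ccc([C@@H]2CC(=O)c3c(O)cc(OCc4cn(Cc5ccc(C)cc5)nn4)cc3O2)cc1O` gives 16800 nM in a functional assay on RAW264.7 cells (Mus musculus) for inhibition, read by Griess assay, with stated times of 2 h and 24 h; on this read-out higher numbers stand for weaker inhibition and lower numbers for stronger inhibition. For the measured compounds named here, the only other measured member, compound 2 `COc1ccc([C@@H]2C/C(=N\O)c3c(O)cc(OCc4cn(Cc5ccccc5Cl)nn4)cc3O2)cc1O`, gives 13400 nM in this assay; the two numbers stand within the scatter of each other, so compound 1 and compound 2 cannot be told apart on this read-out, and no step between measured compounds differing in one place is available.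

Compound 3 `COc1ccc([C@@H]2CC(=O)c3c(O)cc(OCc4cn(C5CCC5)nn4)cc3O2)cc1O` is not yet measured. Against compound 1 the change is cyclobutyl in place of 4-methylbenzyl on an aromatic nitrogen. Going by the values given here, with no measured step to draw on, the expectation for compound 3 is that the number stays close to that of compound 1, with a step of a 1.2-fold higher number from compound 1 to compound 3 (0.08 log units; within the scatter) that need not reach beyond the scatter. The estimate for compound 3 in this assay is 20000 nM, expected to fall between 8000 nM and 50000 nM.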

Compound 3, half-maximal inhibitory concentration: 15300 nM
Compound 3: the middle estimate sits 1.3-fold (0.12 log units) above what was measured; the range from low to high includes it.
By their numbers in this assay, from the lowest: compounds 2, 3 and 1 (each within the scatter of the next).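

In this assay, for the compounds shown here, cyclobutyl in place of 4-methylbenzyl on an aromatic nitrogen of the five-membered aromatic ring with 3 nitrogen gives a 1.1-fold lower number from compound 1 to compound 3 (0.04 log units; within the scatter) and is the first step read at this position. The group on that nitrogen goes from 8 heavy atoms with a six-membered aromatic ring to 4 heavy atoms with a four-membered non-aromatic ring, yet this read-out does not separate the two groups on the shared core. No supporting measurement bears on this result.

On these data alone, whether an aminoethyl group, a carboxylic acid or a longer alkyl chain on this nitrogen would give a step beyond the scatter remains open. Compound 2 differs from compound 1 and compound 3 in more than one place, so the oxime in place of the carbonyl cannot be read.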